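Removing the methoxy group: compound 3 to compound 4

The source may report more compounds than this note shows. Statements on the series, on what has been measured and on what is new or still open speak of the compounds shown alone.

Three chalcones carrying a hydroxy group on the ketone-side ring have been measured in an assay on isolated protein for inhibition of DNA topoisomerase 1 (Homo sapiens), tested at 100 uM; a lower number here means a weaker effect, a higher number a stronger effect of the compound at the concentration tested. Compound 1 `O=C(/C=C/c1ccc(N2CCCC2)cc1)c1ccc(O)cc1` gives 74.7%. Compound 2 `O=C(/C=C/c1ccc(F)cc1)c1ccc(O)cc1O` gives 80.2%. Compound 3 `COc1cc(O)ccc1C(=O)/C=C/c1ccc(F)cc1` gives 86.1%. The number for compound 3 is matched within the scatter by compound 2 and stands beyond the scatter only over compound 1.

For the measured compounds named here, the single step measured so far, a number 5.9 percentage points higher from compound 2 to compound 3 (within the scatter), exchanges a hydrogen for a methyl on an oxygen, and it lies within the scatter. Compound 4 `O=C(/C=C/c1ccc(F)cc1)c1ccc(O)cc1` has not yet been measured. It differs from compound 3 as follows: hydrogen in place of methoxy on an aromatic carbon. This is a different kind of change, deletion of the whole group rather than capping of the oxygen, so the step from compound 2 to compound 3 bears on it only loosely. Going by the values given here, compound 1, which also carries a single hydroxy group and nothing else on that ring, shows a number some way below compound 3, but the other ring differs, so no step is counted between the two.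

On this basis the step of a number 8.1 percentage points lower from compound 3 to compound 4 (within the scatter) is expected to fall within the scatter, with a slight lean downward. Compound 4 is estimated at 78%, within 64% to 90%.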

Compound 4, a percentage reported as inhibition, at one concentration (the size of the read-out at that concentration, not a potency): 50.9%
Beside the measured number, compound 4's estimate is 27.1 percentage points above it, and the stated range ends above it.
By their numbers in this assay, from the lowest: compound 4; then compounds 1, 2 and 3 (each within the scatter of the next, the first and the last beyond it).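

In this assay the carbon ortho to a large group and meta to a hydroxy group proves sensitive to what it carries: deleting the methoxy group gives a number 35.2 percentage points lower from compound 3 to compound 4 (beyond the scatter), and replacing the hydroxy group of compound 2 with hydrogen gives a number 29.3 percentage points lower from compound 2 to compound 4 (beyond the scatter). Hydroxy and methoxy at this carbon remain within the scatter of each other, so either group retains the higher read-out, whereas hydrogen does not, and compound 4 is the weakest of the four at the single concentration tested. The other ring also matters once this carbon bears hydrogen, as fluoro in place of pyrrolidin-1-yl gives a number 23.8 percentage points lower from compound 1 to compound 4 (beyond the scatter), although no measurement on hand accounts for either drop.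

From the compounds shown here alone, whether an oxygen-linked group is needed at this carbon remains open, since chloro, an amine or a longer chain such as ethoxy there would test that point. Also open, going by these compounds, is how pyrrolidin-1-yl on the other ring behaves together with methoxy or hydroxy at this carbon, and whether these differences in effect at one concentration carry over to other concentrations.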